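Acetyl to (3-chlorophenyl)carbonyl: from compound 1 toward compound 4

This account rests on a few compounds, and the source may have more. Where it says the series, first, only, none or still open, it means among the compounds named here.

Measured compounds:
compound 1 `CC(=O)N1c2ccccc2CCC1C(=O)Nc1cc(C(F)(F)F)cc(C(F)(F)F)c1` gives > 70000 nM
compound 2 `O=C(Nc1ccccc1C(F)(F)F)C1CCc2ccccc2N1C(=O)c1cccc(Cl)c1` gives 729 nM
compound 3 `CCCCCCCCC(=O)N1c2ccccc2CCC1C(=O)Nc1ccccc1O` gives 45200 nM

All values come from a functional assay on PC-3 cells (Homo sapiens) for cytotoxicity, read by sulforhodamine B assay, with a stated time of 72 h; a higher number here means a weaker inhibitor of growth, a lower number a stronger inhibitor of growth. For compound 1 the figure is a limit of the assay, not a number, namely (the limit of > 70000 nM in this assay, at which 1 of the 3 values shown sits). Compound 2 and compound 3 give numbers, and the gap between them is large.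

Compound 4 `O=C(Nc1cc(C(F)(F)F)cc(C(F)(F)F)c1)C1CCc2ccccc2N1C(=O)c1cccc(Cl)c1` is not yet measured. It differs from compound 1 in one place: 3-chlorophenyl in place of methyl on a carbonyl carbon. Going by the values given here, no step between measured compounds shares this change, so the size must be guessed. Among the compounds with values here, the only measured compound carrying the (3-chlorophenyl)carbonyl is compound 2, which gives 729 nM. Compound 4 is therefore expected at 3000 nM (range 500 nM to 30000 nM). The expected step is an at least 23-fold lower number from compound 1 to compound 4 (1.36 log units; beyond the scatter) toward stronger inhibition, beyond the scatter.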

Compound 4, concentration for 50% growth inhibition: 1050 nM
Estimate against measurement, compound 4: 2.9-fold (0.46 log units) above; measured number inside the range.
By their numbers in this assay, from the lowest: compounds 2 and 4 (each within the scatter of the next); then compound 3. At a limit, above all of these: compound 1.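

In this assay, 3-chlorophenyl in place of methyl on a carbonyl carbon gives an at least 66-fold lower number from compound 1 to compound 4 (1.82 log units; beyond the scatter), the only step shown at this position with the rest of the molecule unchanged. Until now, the (3-chlorophenyl)carbonyl appeared only in compound 2, which had no acetyl partner, so its contribution could not be isolated. Compound 1 stands at a limit, so the size of this step is only a bound: the limit of > 70000 nM in this assay, at which 1 of the 4 values shown sits.

The compounds shown leave open whether the change depends on the ring itself or on its chlorine. A plain phenyl, or a phenyl bearing an amine or a carboxylic acid in place of chlorine, would separate these.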